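The source may hold more compounds than are shown below. What is called first, only, known or untested is meant among the compounds shown, and "the series" means these compounds.

Measured so far in a functional assay on IMR-32 cells (Homo sapiens) for cytotoxicity, read by sulforhodamine B assay, with a stated time of 48 h; on this read-out lower numbers stand for stronger inhibition and higher numbers for weaker inhibition:
Compound 1 `CC1=C(/C=C/C(=O)/C=C/c2ccc(Cl)cc2)C(C)(C)CCC1` gives 52300 nM.
Compound 2 `CC1=C(/C=C/C(=O)/C=C/c2ccc(C#N)cc2)C(C)(C)CCC1` gives 23400 nM.

Among these two numbers compound 1 stands highest, and compound 2 is its only neighbour: a 2.2-fold lower number from compound 1 to compound 2 (0.35 log units; beyond the scatter). Compound 3 `CC1=C(/C=C/C(=O)/C=C/c2ccccc2Cl)C(C)(C)CCC1` has not yet been measured. It is built from the same atoms as compound 1, joined differently: 2-chlorophenyl in place of 4-chlorophenyl on a double-bonded chain carbon bound to a double-bonded chain carbon. Going by the values given here, the single measured step exchanged one group for another at the same place; it does not test the change from a 4-chlorophenyl to a 2-chlorophenyl, so it bears only loosely on compound 3 and offers no direction. With nothing in the data pointing either way, the step to compound 3 is expected to stay within the scatter, a 1.2-fold lower number from compound 1 to compound 3 (0.07 log units; within the scatter). Compound 3 is therefore estimated at 45000 nM, with a range from 15000 nM to 150000 nM.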

Compound 3, half-maximal inhibitory concentration: 13700 nM
The estimate for compound 3 lay 3.3-fold (0.52 log units) above the measured number, and the stated range ends above it.
By their numbers in this assay, from the lowest: compounds 3 and 2 (each within the scatter of the next); then compound 1.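

Compound 1 and compound 3 have the same atoms and differ only in how the chlorophenyl group is joined, so this comparison isolates the arrangement of that group, which the earlier swap of one group for another could not do. In this assay, replacing 4-chlorophenyl with 2-chlorophenyl gives a 3.8-fold lower number from compound 1 to compound 3 (0.58 log units; beyond the scatter), so this arrangement alone changes the read-out, even with the same atoms and the same counted features. Nothing available explains why this change lowers the number.

As far as these compounds go, it remains open whether a methoxy group or an amine in place of the chlorine on the 2-chlorophenyl group would keep this lower number. The compounds shown also leave open whether the same change would lower the number on cells other than these.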